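This account rests on a few compounds, and the source may have more. Where it says the series, first, only, none or still open, it means among the compounds named here.

Among the measured compounds shown here, compound 1 `COc1ccc(C(=O)/C=C/c2cc(-c3cc(OC)c(OC)c(OC)c3)n[nH]2)cc1OC` is one of two compounds measured in a functional assay on NCI-H460 cells (Homo sapiens) for inhibition, read by sulforhodamine B assay, with a stated time of 48 h; a higher number here means a weaker inhibitor of growth, a lower number a stronger inhibitor of growth: compound 1 gives 1410 nM, the lower of the two numbers, and compound 2 `COc1cc(-c2cc(/C=C/C(=O)c3ccc(F)c(F)c3)[nH]n2)cc(OC)c1OC` gives 2960 nM. For the measured compounds named here, the only measured step, a 2.1-fold higher number from compound 1 to compound 2 (0.32 log units; beyond the scatter), swaps the whole ring on the carbonyl carbon. Compound 3 `COc1cc(C(=O)/C=C/c2cc(-c3cc(OC)c(OC)c(OC)c3)n[nH]2)cc(OC)c1OC` differs from compound 1 by methoxy in place of hydrogen on an aromatic carbon. Going by the values given here, no measured step adds a methoxy to an existing ring, so the expectation in this assay is a step no larger than the scatter, in either direction. Compound 3 is therefore estimated at 1200 nM, with a range from 500 nM to 3000 nM. The expected step of a 1.2-fold lower number from compound 1 to compound 3 (0.07 log units; within the scatter) is small.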

Compound 3, concentration for 50% growth inhibition: 1890 nM
Compound 3: the middle estimate sits 1.6-fold (0.20 log units) below what was measured, within the range that was stated.
By their numbers in this assay, from the lowest: compounds 1, 3 and 2 (each within the scatter of the next, the first and the last beyond it).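

In this assay, placing a further methoxy on the ring at the carbonyl carbon, ortho to a methoxy group, gives a 1.3-fold higher number from compound 1 to compound 3 (0.13 log units; within the scatter). This position therefore accepts the added methoxy, with no difference that can be told from the scatter. Nothing available explains this result.

A single step at one position cannot show whether the same holds for other groups. A hydroxyl, an amine or a longer alkoxy chain at this position remains an open question, in this assay as in any other.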